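Chloro in Place of Hydroxy on a Shared Aromatic Core

This account rests on a few compounds, and the source may have more. Where it says the series, first, only, none or still open, it means among the compounds named here.

Compound 1 `OCc1cc(F)cc(C2=NCCCC2)c1` gives 744 nM in an assay on cell membranes for displacement of a labelled ligand from Neuronal acetylcholine receptor; alpha4/beta2 (Rattus norvegicus), read by radioligand binding, with a stated time of 30 min; on this read-out lower numbers stand for stronger inhibition and higher numbers for weaker inhibition.
Compound 2 `Oc1cccc(C2=NCCCC2)c1` gives 32000 nM in the same test.

Of the two measured compounds, compound 2 has the higher number, which on this read-out means weaker inhibition; the gap to compound 1 lies well beyond the usual scatter of repeated measurements. Compound 3 `Clc1cccc(C2=NCCCC2)c1` differs from compound 2 in a single place: chloro in place of hydroxy on an aromatic carbon. Among the compounds with values here, no measured pair shows this same exchange, so the effect of a chloro in place of hydroxy on an aromatic carbon has to be judged from the two values alone. Since compound 2 stands at the weak end with 32000 nM, there is room to move downward. The step from compound 2 to compound 3 is expected to be a 9.1-fold lower number from compound 2 to compound 3 (0.96 log units; beyond the scatter), toward a lower number and beyond the scatter. Compound 3 is estimated at 3500 nM, with a range from 700 nM to 16000 nM.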

Compound 3, inhibition constant: 11500 nM
For compound 3 the middle estimate is 3.3-fold (0.52 log units) below the measured one; the measured number falls inside the stated range.
By their numbers in this assay, from the lowest: compound 1; then compound 3; then compound 2.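

In this assay, chloro in place of hydroxy on this aromatic carbon gives a 2.8-fold lower number from compound 2 to compound 3 (0.44 log units; beyond the scatter), so this exchange brings a modest gain in inhibition that stands clear of the usual scatter. This pair also shows that hydroxy can be removed from this position without weakening inhibition, even though chloro has no hydrogen-bond donor or acceptor. No measurement shown here explains why the number falls.

One exchange cannot tell whether the gain comes from adding chloro or from removing hydroxy, since both happen in the same step. The compounds shown leave open how a methyl, a methoxy or an amine on the same aromatic carbon would compare, and such groups could help separate those two possibilities.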